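The source may hold more compounds than are shown below. What is called first, only, known or untested is meant among the compounds shown, and "the series" means these compounds.

Of the compounds shown here, three sharing one core have been measured in an assay on Prostate gland for inhibition of steroid 5-alpha-reductase (Rattus norvegicus); on this read-out lower numbers stand for stronger inhibition and higher numbers for weaker inhibition. Compound 1 `CCCC(C(C)C)n1ccc2cc(/C(C)=C/C(=O)Nc3ccccc3OCCCC(=O)O)ccc21` gives 7.2 nM, and compound 2 `CCCCC(C)n1ccc2cc(/C(C)=C/C(=O)Nc3ccccc3OCCCC(=O)O)ccc21` gives 6 nM; between them there is a 1.2-fold lower number from compound 1 to compound 2 (0.08 log units; within the scatter). Compound 3 `C/C(=C\C(=O)Nc1ccccc1OCCCC(=O)O)c1ccc2c(ccn2Cc2ccccc2C)c1` gives 69 nM, the highest of the three numbers and so the weakest inhibition among them: there is a 9.6-fold higher number from compound 1 to compound 3 (0.98 log units; beyond the scatter), and a 12-fold higher number from compound 2 to compound 3 (1.06 log units; beyond the scatter). Both of those steps replace a saturated chain on the aromatic nitrogen with a substituted benzyl group.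

Compound 4 `C/C(=C\C(=O)Nc1ccccc1OCCCC(=O)O)c1ccc2c(ccn2Cc2ccc(F)cc2)c1` keeps that benzyl group and changes only what sits on it: 4-fluorophenyl in place of 2-methylphenyl on a saturated chain carbon bound to an aromatic nitrogen. Among the compounds with values here, none of the measured steps bears directly on this change, since each of them exchanges the whole group on the aromatic nitrogen rather than a substituent on the benzyl ring. Within the data shown here, the measured steps show only that the benzyl compound stands well apart from the two chain compounds; whether a methyl or a fluorine on that ring makes any difference is untested. With no guide either way, the step of a 1.2-fold lower number from compound 3 to compound 4 (0.06 log units; within the scatter) is expected, and is estimated to stay within the scatter. Compound 4 is therefore expected to give about 60 nM in this assay, with an estimated range from 20 nM to 200 nM.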

Compound 4, half-maximal inhibitory concentration: 97 nM
Compound 4: middle estimate off by 1.6-fold (0.21 log units), on the low side, and the stated range covers the measured number.
By their numbers in this assay, from the lowest: compounds 2 and 1 (each within the scatter of the next); then compounds 3 and 4 (each within the scatter of the next).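

In this assay the two ring patterns on the benzyl group cannot be told apart, since the step of a 1.4-fold higher number from compound 3 to compound 4 (0.15 log units; within the scatter) shows that 4-fluorophenyl in place of 2-methylphenyl on this saturated chain carbon bound to an aromatic nitrogen moves the number by no more than the usual scatter. The gap to the saturated chains now holds for a second benzyl group, with a 16-fold higher number from compound 2 to compound 4 (1.21 log units; beyond the scatter) and a 13-fold higher number from compound 1 to compound 4 (1.13 log units; beyond the scatter) both beyond the scatter, so it does not belong to the 2-methylbenzyl group alone: both benzyl compounds give higher numbers than both chain compounds, and none of the four goes against this. No measurement is available that would explain either the closeness of the two benzyl compounds or their distance from the chain compounds.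

As far as these compounds go, compounds 3 and 4 differ in both the substituent and its place on the ring, so the effect of each alone remains unknown, and a 4-methylbenzyl or 2-fluorobenzyl group would separate the two. Also open, from the compounds shown here alone, is whether a plain benzyl group, or a 4-methoxybenzyl group, would stay with compounds 3 and 4 or come closer to compounds 1 and 2.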